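The source may hold more compounds than are shown below. What is called first, only, known or untested is meant among the compounds shown, and "the series" means these compounds.

The measured compounds:

compound 1, `O=C1Nc2ccc(S(=O)(=O)N3CCOCC3)cc2/C1=N/NC(=O)c1ccccc1` — 18100 nM
compound 2, `O=C1Nc2ccc(S(=O)(=O)N3CCOCC3)cc2/C1=N/c1ccc(O)cc1` — 10400 nM
compound 3, `O=C1Nc2ccc(S(=O)(=O)N3CCOCC3)cc2/C1=N/c1cccc(C(F)(F)F)c1` — 14300 nM

All three share one core and differ only in the group carried on the double-bonded nitrogen. In a functional assay on HepG2 cells (Homo sapiens) for cytotoxicity, read by sulforhodamine B assay, with a stated time of 24 h (a lower number here means a stronger inhibitor, a higher number a weaker inhibitor), compound 1 gives 18100 nM, compound 2 gives 10400 nM and compound 3 gives 14300 nM. Compound 3 stands as the second highest of the three numbers; its nearest neighbour is compound 1, with a 1.3-fold lower number from compound 1 to compound 3 (0.10 log units; within the scatter), and the one furthest from it is compound 2, with a 1.4-fold higher number from compound 2 to compound 3 (0.14 log units; within the scatter). The third step, a 1.7-fold lower number from compound 1 to compound 2 (0.24 log units; within the scatter), is likewise within the scatter, so the three groups on the double-bonded nitrogen are not told apart in this assay.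

Compound 4 is `O=C1Nc2ccc(S(=O)(=O)N3CCOCC3)cc2/C1=N/c1ccc(C(=O)O)cc1`. It differs from compound 3 as follows: 4-carboxyphenyl in place of 3-(trifluoromethyl)phenyl on a double-bonded nitrogen.

Every step that bears on this change is a swap of the group on the double-bonded nitrogen, and none of them moved the number beyond the scatter. On that basis compound 4 is expected to stay close to compound 3, with an estimated step of a 1.1-fold lower number from compound 3 to compound 4 (0.04 log units; within the scatter), that is, none beyond the scatter. The estimate for compound 4 in this assay is 13000 nM, with a range from 6000 nM to 30000 nM.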

Compound 4, half-maximal inhibitory concentration: 23100 nM
The estimate for compound 4 lay 1.8-fold (0.25 log units) below the measured number; low and high end bracket the measured number.
By their numbers in this assay, from the lowest: compounds 2, 3, 1 and 4 (each within the scatter of the next, the first and the last beyond it).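

Among the compounds shown here, replacing hydroxy with carboxy on the aromatic ring gives the first step at this position that lies beyond the scatter (a 2.2-fold higher number from compound 2 to compound 4 (0.35 log units; beyond the scatter)), although it is only modest, so in this assay the group on the double-bonded nitrogen is no longer entirely without a detectable effect. The separation is limited to this one pair, since compound 4 is not told apart from the other two compounds, as seen in the steps (a 1.6-fold higher number from compound 3 to compound 4 (0.21 log units; within the scatter)) and (a 1.3-fold higher number from compound 1 to compound 4 (0.11 log units; within the scatter)), both of which stay within the scatter. The compounds shown come with no supporting measurement that could explain why carboxy and hydroxy differ here.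

For the compounds shown here, the single pair cannot show whether the step belongs to the carboxy group itself, and a methyl ester or an amide of the carboxylic acid on the same ring would test that directly. Going by these compounds, it also remains open whether an amine on this ring, or a longer chain carrying the carboxylic acid, would move the number any further than carboxy does in compound 4.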